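The compounds below may be only part of what the source reports. "The series", "measured", "known", "first", "only" and "open" are said of these compounds alone.

In a functional assay on NCI-H460 cells (Homo sapiens) for cytotoxicity, read by MTT assay, with a stated time of 72 h (on this read-out lower numbers stand for stronger inhibition and higher numbers for weaker inhibition), the measured compounds read as follows:

Compound 1 `CC(C)(C)c1[nH]cnc1/C=c1\[nH]c(=O)/c(=C/c2cccc(C(=O)c3ccc(F)cc3)c2)[nH]c1=O`: 3.8 nM
Compound 2 `O=C(c1ccc(F)cc1)c1cccc(/C=c2\[nH]c(=O)/c(=C/c3c[nH]cn3)[nH]c2=O)c1`: 278 nM
Compound 3 `O=c1[nH]/c(=C\c2ccccn2)c(=O)[nH]/c1=C\c1cccc(Oc2ccc(F)cc2)c1`: 49.1 nM

Compound 3 at 49.1 nM stands in the middle of the three, beyond the scatter from both neighbours: compound 1 at 3.8 nM lies lower and compound 2 at 278 nM lies higher.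

The next compound is compound 4 `O=c1[nH]/c(=C\c2ccc(Cl)o2)c(=O)[nH]/c1=C\c1cccc(Oc2ccc(F)cc2)c1`, and its difference from compound 3 is 5-chlorofuran-2-yl in place of pyridin-2-yl on a double-bonded chain carbon bound to an aromatic carbon.

Among the measured compounds shown here, only one measured step links two compounds that differ in one place: a 73-fold higher number from compound 1 to compound 2 (1.86 log units; beyond the scatter), a large step for hydrogen in place of tert-butyl on an aromatic carbon. That step involves neither pyridin-2-yl nor 5-chlorofuran-2-yl, so it bears on this change only indirectly. It shows that a single change can move the number a long way in this assay and argues for a wide range. For the measured compounds named here, no measured step gives a direction for this exchange, so no step beyond the scatter is expected. The expected change is a 1.1-fold lower number from compound 3 to compound 4 (0.04 log units; within the scatter) in this estimate. For compound 4 the estimated value is 45 nM, with an expected range from 12 nM to 170 nM.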

Compound 4, half-maximal inhibitory concentration: 180 nM
Compound 4: the middle estimate sits 4.0-fold (0.60 log units) below what was measured; the whole stated range lies below it.
By their numbers in this assay, from the lowest: compound 1; then compound 3; then compounds 4 and 2 (each within the scatter of the next).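

In this assay, the exchange at this double-bonded chain carbon gives a 3.7-fold higher number from compound 3 to compound 4 (0.56 log units; beyond the scatter), a modest step beyond the scatter and the first measured one at this place, so the ring held here matters even with the rest of the structure unchanged. The counts computed for the two groups match in heavy atoms, hydrogen-bond donors, hydrogen-bond acceptors and net charge, so those counts do not distinguish them; what differs is the ring size and the atoms present, with a five-membered ring carrying oxygen and chlorine replacing a six-membered ring carrying nitrogen. No measurement is available that bears on why the number rose, so the step stands here without an explanation.

The compounds shown do not separate the contribution of the chlorine from that of the five-membered ring, and they leave open whether a methyl group or an amine in place of that chlorine would give a higher or a lower number. They also leave open whether the same exchange would give a step of similar size on the structure of compound 1 or compound 2, which differ from compound 3 elsewhere.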